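The compounds below may be only part of what the source reports. "The series", "measured", "known", "first", "only" and "open" are said of these compounds alone.

Compound 2, `CCOC(=O)/C=C/c1ccc(OC(=O)c2nc(C)c(C)nc2C)cc1`, stands highest among the three compounds measured in a functional assay on EA.hy 926 cells (Homo sapiens) for cytotoxicity, read by MTT assay, with stated times of 24 h and 12 h, tested at 25 uM; on this read-out higher numbers stand for a stronger effect at the one concentration tested and lower numbers for a weaker effect: compound 2 gives 58.8%, compound 3, `Cc1nc(C)c(C(=O)Oc2ccc(/C=C/C(=O)O)cc2)nc1C`, gives 46.6%, and compound 1, `CCOC(=O)/C=C/c1cc(OC)c(OC(=O)c2nc(C)c(C)nc2C)c(OC)c1`, gives 20.9%. For the measured compounds named here, the only single-place step measured is a number 12.2 percentage points lower from compound 2 to compound 3 (beyond the scatter), which does not touch the ring bearing the ester. Compound 4, `CCOC(=O)/C=C/c1ccc(OC(=O)c2nc(C)c(C)nc2C)c(OC)c1`, differs from compound 2 by methoxy in place of hydrogen on an aromatic carbon. Going by the values given here, no measured step bears directly on this change; compound 1, which carries two methoxy groups on that ring, gives 20.9%, whereas compound 2 gives 58.8%, so a lower number is expected. Compound 4 is therefore estimated at 40%, between 22% and 58%, a step of a number 18.8 percentage points lower from compound 2 to compound 4 (beyond the scatter).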

Compound 4, a percentage reported as activity, at one concentration (the size of the read-out at that concentration, not a potency): 53.3%
For compound 4 the middle estimate is 13.3 percentage points below the measured one; measured number inside the range.
By their numbers in this assay, from the lowest: compound 1; then compounds 3, 4 and 2 (each within the scatter of the next, the first and the last beyond it).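

In this assay, a single methoxy ortho to a large group leaves the number within the scatter (a number 5.5 percentage points lower from compound 2 to compound 4 (within the scatter)). The large step appears only when the second methoxy of compound 1 is replaced by hydrogen (a number 32.4 percentage points higher from compound 1 to compound 4 (beyond the scatter)), so on this ring one methoxy and two methoxy groups do not read alike. Nothing available explains either result.

The compounds shown leave open how a hydroxyl, an amine or a fluorine at this position would read. They also leave open whether a single methoxy would read the same with the carboxylic acid of compound 3 in place of the ethyl ester.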